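This account rests on a few compounds, and the source may have more. Where it says the series, first, only, none or still open, it means among the compounds named here.

Values so far in a functional assay on SW-620 cells (Homo sapiens) for cytotoxicity, read by MTT assay, with stated times of 4 h and 72 h, tested at 2 uM (a higher number here means a weaker inhibitor, a lower number a stronger inhibitor), for three compounds:
- compound 1 `Cc1cc(Nc2ccc(C(=O)/C=C/c3ccc4ccccc4c3)cc2)n2nc(SCc3cccc4ccccc34)nc2n1` gives 68 nM
- compound 2 `Cc1cc(Nc2ccc(C(=O)/C=C/c3ccccc3)cc2)n2nc(SCc3nc4ccccc4[nH]3)nc2n1` gives 130 nM
- compound 3 `Cc1cc(Nc2ccc(C(=O)/C=C/c3ccc4ccccc4c3)cc2)n2nc(SCC(=O)c3ccccc3)nc2n1` gives 190 nM

Compound 2 at 130 nM sits within the usual scatter of both other compounds, so it cannot be ranked against either. Compound 4 `Cc1cc(Nc2ccc(C(=O)/C=C/c3ccc(-n4cccn4)cc3)cc2)n2nc(SCc3nc4ccccc4[nH]3)nc2n1` is compound 2 with a single change, and that change is 1H-pyrazol-1-yl in place of hydrogen on an aromatic carbon in which 1H-pyrazol-1-yl takes the place of hydrogen on an aromatic carbon, para to a large group, turning phenyl into 4-(1H-pyrazol-1-yl)phenyl.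

Within the data shown here, only one measured step exists, a 2.8-fold higher number from compound 1 to compound 3 (0.45 log units; beyond the scatter) and it is modest. It lies on the sulfur side of the molecule, not on this ring, so it offers only a rough guide to size. Among the measured compounds shown here, no measured pair tests a group added at this place, which leaves the direction open. The expected step is a 1.2-fold higher number from compound 2 to compound 4 (0.09 log units; within the scatter) and no shift clearly beyond the scatter is anticipated. In this assay compound 4 is estimated at 160 nM with an expected range of 50 nM to 500 nM as the likely span.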

Compound 4, half-maximal inhibitory concentration: 340 nM
The estimate for compound 4 lay 2.1-fold (0.33 log units) below the measured number, and the stated range covers the measured number.
By their numbers in this assay, from the lowest: compounds 1, 2, 3 and 4 (each within the scatter of the next, the first and the last beyond it).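

In this assay, adding 1H-pyrazol-1-yl on an aromatic carbon para to a large group, which turns phenyl into 4-(1H-pyrazol-1-yl)phenyl, gives a 2.6-fold higher number from compound 2 to compound 4 (0.42 log units; beyond the scatter) and so a modestly weaker inhibitor. Among these compounds, the only earlier step lay on the sulfur side of the molecule, so this is the first sign that the number responds to a change at this place, and that this group moves it upward. Nothing measured here explains the shift, so its cause remains unknown.

From the compounds shown here alone, whether a smaller group at this place, such as fluorine, methoxy or an amine, would also weaken inhibition remains open. Going by these compounds, it is also open whether 1H-pyrazol-1-yl would have a similar effect alongside a different group on the sulfur, such as the naphthalen-1-ylmethyl group of compound 1.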